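The source may report more compounds than this note shows. Statements on the series, on what has been measured and on what is new or still open speak of the compounds shown alone.

Measured compounds:
- compound 1 `C[C@@H]1CN(c2ncccc2C(F)(F)F)CCN1C(=O)Nc1ccc(C(F)(F)F)cc1`: 11 nM
- compound 2 `O=C(Nc1ccccc1)c1ccc(-c2ncccc2C(F)(F)F)cc1`: "not determined" (no result reported)
- compound 3 `CC(C)(C)c1ccc(NC(=O)c2ccc(-c3ncccc3NS(C)(=O)=O)cc2)cc1`: 35 nM

Three compounds were examined in a functional assay for antagonist activity at transient receptor potential cation channel subfamily V member 1 (Rattus norvegicus); on this read-out lower numbers stand for stronger inhibition and higher numbers for weaker inhibition. Compound 1 gives 11 nM in this assay. For compound 2 no number was recorded in this assay. Compound 3 gives 35 nM in this assay, the higher of the two numbers reported; the gap to compound 1 is beyond the scatter, so compound 3 inhibits more weakly than compound 1.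

Compound 4 `Cc1nnc(-c2cccnc2-c2ccc(C(=O)Nc3ccc(C(C)(C)C)cc3)cc2)o1` keeps the core of compound 3 and differs in one place: 5-methyl-1,3,4-oxadiazol-2-yl in place of methanesulfonamido on an aromatic carbon. Among the measured compounds shown here, no pair of measured compounds differing in exactly this way is available, so the size of this step is not known from the data. The groups are of similar size, one hydrogen-bond donor leaves and an extra acceptor enters, and the change sits on the core rather than in the amide part shared with compound 3. The expectation is a step of no more than modest size, in either direction, for compound 4, with a 1.1-fold higher number from compound 3 to compound 4 (0.06 log units; within the scatter) as the estimated change. Compound 4 is therefore estimated at 40 nM in this assay, within a range from 10 nM to 160 nM.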

Compound 4, half-maximal inhibitory concentration: 34 nM
Compound 4: middle estimate off by 1.2-fold (0.07 log units), on the high side, within the range that was stated.
By their numbers in this assay, from the lowest: compound 1; then compounds 4 and 3 (each within the scatter of the next).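

In this assay, placing 5-methyl-1,3,4-oxadiazol-2-yl instead of methanesulfonamido on this aromatic carbon, two atoms from the ring nitrogen, gives a 1.0-fold lower number from compound 3 to compound 4 (0.01 log units; within the scatter) and so leaves inhibition effectively unchanged. For this pair, the hydrogen-bond donor of the methanesulfonamido group is not needed to keep this level of inhibition, and a five-membered aromatic ring can take its place without a step beyond the scatter. No measurement here explains why these two different groups give matching numbers.

Going by these compounds, whether an amine, a carboxylic acid or a simple methyl group at this position would also keep inhibition at this level remains open. On these data alone, it is also open whether the same exchange would give so small a step on a different core, such as that of compound 1.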